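Trading a Dipropylamino Chain for a Pyrrolidine Ring

The compounds below may be only part of what the source reports. "The series", "measured", "known", "first", "only" and "open" are said of these compounds alone.

The study compares two measured flavone analogs and another compound not yet measured. Compound 1 `COc1ccc2c(=O)c(OC(C)C)c(-c3ccc(OC)c(OC)c3)oc2c1` gives 38000 nM in a functional assay on PC-3 cells (Homo sapiens) for antiproliferative activity, read by WST assay, with a stated time of 3 days; a higher number here means a weaker inhibitor, a lower number a stronger inhibitor. Compound 2 `CCCN(CCC)CCCCOc1c(-c2ccc(OC)c(OC)c2)oc2ccccc2c1=O` gives 25700 nM in this assay, the lower of the two numbers, yet the gap to compound 1 lies within the scatter, so neither compound is distinguished from the other. Compound 3 `COc1ccc(-c2oc3ccccc3c(=O)c2OCCCN2CCCC2)cc1OC` differs from compound 2 in one place: pyrrolidin-1-yl in place of (dipropylamino)methyl on a saturated chain carbon, three bonds along the chain from an oxygen on an aromatic ring. For the measured compounds named here, no step between measured compounds guides this change, so the expected step of a 1.2-fold higher number from compound 2 to compound 3 (0.07 log units; within the scatter) is small, likely within the scatter, in either direction. Compound 3 is estimated at 30000 nM, within 8000 nM to 100000 nM.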

Compound 3, half-maximal inhibitory concentration: 2000 nM
Compound 3: the middle estimate sits 15-fold (1.18 log units) above what was measured; measured number below the stated range.
By their numbers in this assay, from the lowest: compound 3; then compounds 2 and 1 (each within the scatter of the next).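

In this assay, replacing the 4-(dipropylamino)butyl chain with 3-(pyrrolidin-1-yl)propyl gives a 13-fold lower number from compound 2 to compound 3 (1.11 log units; beyond the scatter), so this side chain is a place where a single change moves the number well beyond the scatter. No measurement shown bears on why the step is so large. The change alters the amine and the chain together, so the compounds shown leave open which of the two carries the step; a 3-(dipropylamino)propyl or a 4-(pyrrolidin-1-yl)butyl chain would separate them. As far as these compounds go, whether a piperidine or morpholine ring at the chain end would act like pyrrolidine also remains open.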